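Allyl ethers on a trimethoxy-like cinnamyl core: estimating compound 4

The source may report more compounds than this note shows. Statements on the series, on what has been measured and on what is new or still open speak of the compounds shown alone.

Measured so far:
compound 1 `COc1cc(/C=C/C=O)cc(OC)c1OC/C=C(\C)CCC=C(C)C` – 2600 nM
compound 2 `COc1cc(/C=C/CO)cc(OC)c1OCc1ccccc1` – 860000 nM
compound 3 `COc1cc(/C=C/C=O)cc(OC)c1OCc1ccccc1` – 640000 nM

In a functional assay on KB cells (Homo sapiens) for cytotoxicity, with a stated time of 72 h (on this read-out higher numbers stand for weaker inhibition and lower numbers for stronger inhibition), compound 2 gives the highest number of the three. Among the compounds with values here, its nearest neighbour is compound 3, and the only single-point step in the set, a 1.3-fold lower number from compound 2 to compound 3 (0.13 log units; within the scatter), does not separate the two. Within the data shown here, compound 1, which carries a long chain on the same oxygen and a formyl group, gives a far lower number; no step to compound 1 is computed, so only the two values themselves stand side by side.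

Compound 4 `CC/C(C)=C/Oc1c(OC)cc(/C=C/CO)cc1OC` is not yet measured. It differs from compound 2 in one place: 2-methylbut-1-en-1-yl in place of benzyl on an oxygen on an aromatic ring. Among the measured compounds shown here, no measured step covers this exchange. For the measured compounds named here, the only bearing comes from compound 1, whose chain on that oxygen goes with a much lower number than either benzyl compound, while a 1.3-fold lower number from compound 2 to compound 3 (0.13 log units; within the scatter) shows the hydroxymethyl/formyl pair to be interchangeable. A shorter chain than that of compound 1 is entering, so a move toward lower numbers is expected but of uncertain size. Compound 4 is therefore estimated at 20000 nM (range 2500 nM to 200000 nM), a step of a 43-fold lower number from compound 2 to compound 4 (1.63 log units; beyond the scatter), expected to lie beyond the scatter.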

Compound 4, half-maximal inhibitory concentration: 7800 nM
Estimate against measurement, compound 4: 2.6-fold (0.41 log units) above; low and high end bracket the measured number.
By their numbers in this assay, from the lowest: compound 1; then compound 4; then compounds 3 and 2 (each within the scatter of the next).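

On the oxygen on an aromatic ring, 2-methylbut-1-en-1-yl in place of benzyl gives a large change (a 110-fold lower number from compound 2 to compound 4 (2.04 log units; beyond the scatter)) in this assay and is the only listed step at this position. The exchange at the other end of the molecule stays within the scatter (a 1.3-fold lower number from compound 2 to compound 3 (0.13 log units; within the scatter)), so among the compounds shown, the group on this oxygen is the one change that moves the number beyond the scatter. Compound 4 also shows that a formyl group is not needed for a number this low, and no measurement bearing on the cause of the change is at hand.

A saturated 2-methylbutyl group on this oxygen would show whether the double bond or simply the loss of the ring goes with the change. On these data alone, how a carboxylic acid or an amine in place of the hydroxymethyl would read with this chain remains open.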